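This account rests on a few compounds, and the source may have more. Where it says the series, first, only, none or still open, it means among the compounds named here.

In a functional assay on ECa-109 cells (Homo sapiens) for inhibition, read by MTT assay, with a stated time of 72 h (on this read-out higher numbers stand for weaker inhibition and lower numbers for stronger inhibition), compound 2 `S=C(SCc1cn(Cc2ccccc2Cl)nn1)N1CCNCC1` is known only as a limit, > 128000 nM, rather than as a number. Compound 3 `CC(C)(C)OC(=O)N1CCN(C(=S)SCc2cn(Cc3ccccc3Cl)nn2)CC1` carries a tert-butoxycarbonyl on the ring nitrogen, and in this assay compound 3 gives 11900 nM; the step of an at least 10-fold lower number from compound 2 to compound 3 (1.03 log units; beyond the scatter) shows what that added group does. Compound 1 `O=C(OCc1ccccc1)N1CCN(C(=S)SCc2cn(Cc3ccc(F)cc3)nn2)CC1`, with a benzyloxycarbonyl on the same nitrogen and a 4-fluorophenyl, gives 32000 nM in this assay. Compound 4 `S=C(SCc1cn(Cc2ccc(Cl)cc2)nn1)N1CCNCC1` differs from compound 2 by 4-chlorophenyl in place of 2-chlorophenyl on a saturated chain carbon bound to an aromatic nitrogen. Going by the values given here, no measured step covers such a move of the chlorine while the ring nitrogen keeps its hydrogen, so no change beyond the scatter is expected, and compound 4 is estimated at 150000 nM, between 60000 nM and 400000 nM, a step that the limit leaves unreadable from compound 2 to compound 4 that most likely again ends as a limit, as at the limit of > 128000 nM in this assay, at which 1 of the 3 values shown sits.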

Compound 4, half-maximal inhibitory concentration: > 128000 nM
Compound 4: a limit, no number; the forecaster's own chance of this, stated with the estimate: 70%; the middle value lies beyond the limit too.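

No step can be read between compound 2 and compound 4 because both are known only as limits, not numbers: the limit of > 128000 nM in this assay, at which 2 of the 4 values shown sit.

The compounds shown leave open whether 4-chlorophenyl and 2-chlorophenyl differ in inhibition at all.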